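The source may report more compounds than this note shows. Statements on the series, on what has been measured and on what is new or still open speak of the compounds shown alone.

Compound 1, `O=C(/C=C/c1cccc(OCc2ccccc2)c1)c1ccccc1Br`, sets the low mark among the three compounds measured in a functional assay on BT-20 cells (Homo sapiens) for cytotoxicity, read by MTT assay, with a stated time of 68 h; a lower number here means a stronger inhibitor, a higher number a weaker inhibitor. In that assay compound 1 gives 1800 nM. Compound 2, `COc1ccc(C(=O)/C=C/c2cccc(OCc3ccccc3)c2)cc1`, gives 38300 nM, and compound 3, `O=C(/C=C/c1cccc(OCc2ccccc2)c1)c1cccc(Br)c1`, gives 7100 nM. The two steps that start from compound 1 both raise the number: a 21-fold higher number from compound 1 to compound 2 (1.33 log units; beyond the scatter), and a 3.9-fold higher number from compound 1 to compound 3 (0.60 log units; beyond the scatter). Between the other two, a 5.4-fold lower number from compound 2 to compound 3 (0.73 log units; beyond the scatter).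

Compound 4, `O=C(/C=C/c1cccc(OCc2ccccc2)c1)c1ccc(Cl)cc1Cl`, has not yet been measured. It differs from compound 1 in one place: 2,4-dichlorophenyl in place of 2-bromophenyl on a carbonyl carbon. The step from compound 1 to compound 3 bears on it, since that step also moves a halogen on this ring and costs a modest amount; the step from compound 1 to compound 2 shows that a non-halogen group on this ring costs far more. Compound 4 keeps a halogen where compound 1 has its bromine and adds a second one, so he expects at most a modest rise in this assay, of the order of a 1.7-fold higher number from compound 1 to compound 4 (0.22 log units; within the scatter). His estimate for compound 4 is 3000 nM, with a range from 1200 nM to 8000 nM.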

Compound 4, half-maximal inhibitory concentration: 19200 nM
Beside the measured number, compound 4's estimate is 6.4-fold (0.81 log units) below it; measured number above the stated range.
By their numbers in this assay, from the lowest: compound 1; then compound 3; then compounds 4 and 2 (each within the scatter of the next).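

Holding a halogen on this ring does not by itself hold the number in this assay: 2,4-dichlorophenyl on the carbonyl carbon gives a large step from the 2-bromophenyl compound (an 11-fold higher number from compound 1 to compound 4 (1.03 log units; beyond the scatter)) and a modest one from the 3-bromophenyl compound (a 2.7-fold higher number from compound 3 to compound 4 (0.43 log units; beyond the scatter)). The 4-methoxyphenyl compound no longer stands apart, since the remaining gap lies within the scatter (a 2.0-fold lower number from compound 2 to compound 4 (0.30 log units; within the scatter)), so among these compounds a loss of this size is not confined to the non-halogen group. Nothing measured here accounts for these steps.

Going by these compounds, whether the change follows from chlorine in place of bromine or from the second halogen stays open, and a 2-chlorophenyl group would separate the two. Also open, on these data alone, is what this assay would return with an amine or a carboxylic acid on this ring.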